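A few compounds are considered here, and "the series" means these few. Any claim that something is new, unique, unknown or untested is made for them only; others in the source may bear on it.

Measured compounds:
compound 1, `Fc1ccc(C2CC(c3ccc(Cl)s3)=NN2c2nc(-c3ccccc3)cs2)cc1`: > 500 ug/mL
compound 2, `O=[N+]([O-])c1ccc(-c2csc(N3N=C(c4ccc(Cl)s4)CC3c3ccc(F)cc3)n2)cc1`: > 500 ug/mL
compound 3, `COc1ccc(-c2csc(N3N=C(c4ccc(Cl)s4)CC3c3ccc(F)cc3)n2)cc1`: > 500 ug/mL

In a functional assay on A549 cells (Homo sapiens) for antiproliferative activity, read by XTT assay, with a stated time of 24 h (on this read-out lower numbers stand for stronger inhibition and higher numbers for weaker inhibition), compound 1 gives > 500 ug/mL, which is a limit of the assay and not a number. Compound 2 gives > 500 ug/mL, again a limit. Compound 3 gives > 500 ug/mL, also a limit. All three values therefore sit at the limit of > 500 ug/mL in this assay, at which 3 of the 3 values shown sit, and compound 3 stands no higher and no lower than the others on the numbers shown. Among the compounds with values here, the three measured steps are a step that the two limits leave unreadable from compound 1 to compound 2, a step that the two limits leave unreadable from compound 1 to compound 3 and a step that the two limits leave unreadable from compound 2 to compound 3; none of them has a readable size, so the series so far gives no measured step whose size could be carried over.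

Compound 4, `CS(=O)(=O)c1ccc(-c2csc(N3N=C(c4ccc(Cl)s4)CC3c3ccc(F)cc3)n2)cc1`, is to be measured in this assay. It differs from compound 3 by methylsulfonyl in place of methoxy on an aromatic carbon. The step to be expected from compound 3 to compound 4 is a step that the limit leaves unreadable from compound 3 to compound 4, and with every measured value at the limit, the expectation is that compound 4 will again be reported only as a limit. The estimate for compound 4 is 700 ug/mL, with a range from 200 ug/mL to 2500 ug/mL.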

Compound 4, half-maximal inhibitory concentration: > 500 ug/mL
Compound 4 ended at the assay's limit; the forecaster's own chance of this, stated with the estimate: 80%; the middle value is on the limit's open side.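

Within the data shown here, compound 4 gives > 500 ug/mL in this assay, which is a limit and not a number, so no step from compound 1, compound 2 or compound 3 to compound 4 can be read. Whether hydrogen, nitro, methoxy and methylsulfonyl differ at all in this assay stays open: the limit of > 500 ug/mL in this assay, at which 4 of the 4 values shown sit.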